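Trading an aryl for an arylamino group on the carbonyl

A few compounds are considered here, and "the series" means these few. Any claim that something is new, unique, unknown or untested is made for them only; others in the source may bear on it.

The measured compounds, in a functional assay on OVCAR-8 cells (Homo sapiens) for inhibition, read by sulforhodamine B assay, with a stated time of 48 h; a lower number here means a stronger inhibitor of growth, a higher number a weaker inhibitor of growth:
Compound 1 `O=C(Nc1cccc(-n2cc(-c3ccncc3)c(-c3ccc(Cl)c(O)c3)n2)c1)Nc1cccc(C(F)(F)F)c1` gives > 32500 nM, which is a limit of this assay.
Compound 2 `COc1cc(-c2nn(-c3cccc(NC(=O)Nc4cc(C(F)(F)F)cc(C(F)(F)F)c4)c3)cc2-c2ccncc2)ccc1Cl` gives 3980 nM.
Compound 3 `COc1cc(-c2nn(-c3cccc(NC(=O)c4cccc(C(F)(F)F)c4)c3)cc2-c2ccncc2)ccc1Cl` gives > 50000 nM, which is a limit of this assay.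

Among the compounds with values here, of the three values shown, two are limits and only one is a number, so compound 3 stands on a limit rather than on a measured figure (the limit of > 50000 nM in this assay, at which 1 of the 3 values shown sits), and compound 1 likewise sits on a limit (the limit of > 32500 nM in this assay, at which 1 of the 3 values shown sits). Within the data shown here, compound 2, the only one with a number, carries a (3,4-dichlorophenyl)carbamoyl-like arrangement in that its carbonyl bears an arylamino group; compound 3 differs from it in the group on that carbonyl and in what the aryl carries.

Compound 4 `COc1cc(-c2nn(-c3cccc(NC(=O)Nc4ccc(Cl)c(Cl)c4)c3)cc2-c2ccncc2)ccc1Cl` is not yet measured. It differs from compound 3 by (3,4-dichlorophenyl)amino in place of 3-(trifluoromethyl)phenyl on a carbonyl carbon; read one bond further out, (3-(trifluoromethyl)phenyl)carbonyl becomes (3,4-dichlorophenyl)carbamoyl. This brings compound 4 closer to compound 2, the compound with a number, but compound 1 shows that an arylamino group on the carbonyl does not by itself guarantee a number. A step toward stronger inhibition is therefore expected, an at least 5.5-fold lower number from compound 3 to compound 4 (0.74 log units; beyond the scatter), beyond the usual scatter but with wide uncertainty. Compound 4 is estimated at 9000 nM, within 2000 nM to 40000 nM.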

Compound 4, concentration for total growth inhibition: 3610 nM
For compound 4 the middle estimate is 2.5-fold (0.40 log units) above the measured one, and the stated range covers the measured number.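

In this assay, putting (3,4-dichlorophenyl)amino in place of 3-(trifluoromethyl)phenyl on this carbonyl carbon gives an at least 13-fold lower number from compound 3 to compound 4 (1.14 log units; beyond the scatter) and is the first change shown in one place that separates a compound without a measured number from one with a number. For compound 3 the read-out is a limit and not a number, so the size of the step can only be read as a minimum: the limit of > 50000 nM in this assay, at which 1 of the 4 values shown sits. The change is not a single feature, since the entering group brings one hydrogen-bond donor where the leaving group has none, and two chlorines replace a trifluoromethyl group on the aromatic ring, and the step cannot tell these apart.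

Still open, from the compounds shown here alone, is whether the new amino nitrogen or the change on the ring carries the step, and compound 1 cannot settle this, as it has a 3-(trifluoromethyl)phenylamino group but also differs from compound 3 in a second place. Also open, going by these compounds, is how this assay would read with a non-aromatic group on this carbonyl, such as a cyclohexylamino group.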